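This account rests on a few compounds, and the source may have more. Where it says the series, first, only, none or still open, it means among the compounds named here.

Compound 2 `CC(C)(C)N1C(=O)C=C(Cl)C1(O)c1ccccc1` gives 120 nM in an assay on cell membranes for displacement of a labelled ligand from Cholecystokinin receptor type A (Rattus norvegicus), read by CCK-8 assay, with a stated time of 2 h (a lower number here means a stronger inhibitor, a higher number a weaker inhibitor), the lower of the two numbers recorded so far. For the measured compounds named here, compound 1 `O=C1C=C(Cl)C(O)(c2ccccc2)N1C1CC1` gives 7500 nM in this assay, and the single measured step between them, a 63-fold lower number from compound 1 to compound 2 (1.80 log units; beyond the scatter), is large and well beyond the scatter. Compound 3 `CCCCCCN1C(=O)C=C(Cl)C1(O)c1ccccc1` has not yet been measured; it differs from compound 2 by hexyl in place of tert-butyl on an amide-type nitrogen in a ring. Going by the values given here, the only measured step that bears on this change is the one from compound 1 to compound 2, which also exchanged the group on that ring nitrogen: it shows that this position can shift the number a great deal, but it does not show which way a hexyl chain will go. A step beyond the scatter is therefore expected, on balance toward a higher number, a 5.0-fold higher number from compound 2 to compound 3 (0.70 log units; beyond the scatter). Compound 3 is estimated at 600 nM in this assay, with a range from 100 nM to 4000 nM.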

Compound 3, half-maximal inhibitory concentration: 4500 nM
Beside the measured number, compound 3's estimate is 7.5-fold (0.88 log units) below it, outside the stated range (above it).
By their numbers in this assay, from the lowest: compound 2; then compounds 3 and 1 (each within the scatter of the next).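

Hexyl in place of tert-butyl gives a 38-fold higher number from compound 2 to compound 3 (1.57 log units; beyond the scatter) in this assay and thus loses the low number of compound 2, so a larger open chain on the amide-type nitrogen does not keep what tert-butyl gave. Hexyl in place of cyclopropyl gives a 1.7-fold lower number from compound 1 to compound 3 (0.22 log units; within the scatter) and lies within the scatter, so compound 1 and compound 3 cannot be told apart in this assay even though one carries a ring and the other an open chain. Among these three groups, only tert-butyl gives a number set apart from the others.

The compounds shown leave open whether isopropyl, neopentyl or a shorter chain such as butyl would stand nearer to tert-butyl or to hexyl. They also leave open how an amine or a carboxylic acid at the end of the hexyl chain would shift the number. Nothing given here explains the behaviour of tert-butyl at this position.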